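Methoxy for chloro on the aryl ring of compound 1

The source may report more compounds than this note shows. Statements on the series, on what has been measured and on what is new or still open speak of the compounds shown alone.

Three chalcone-type compounds sharing one core have been measured in a functional assay on SW-620 cells (Homo sapiens) for inhibition; on this read-out lower numbers stand for stronger inhibition of growth and higher numbers for weaker inhibition of growth. Compound 1 `COc1cc(/C=C/C(=O)c2cccc(-n3cc(-c4ccc(Cl)cc4)[nH]c3=O)c2)cc(OC)c1OC` gives 1750 nM in this assay. Compound 2 `O=C(/C=C/c1cccc(O)c1)c1cccc(-n2cc(-c3ccccc3)[nH]c2=O)c1` gives 2410 nM, and compound 3 `O=C(/C=C/c1cccc(O)c1)c1cccc(-n2cc(-c3ccc(Cl)cc3)[nH]c2=O)c1` gives 1620 nM. Compound 1 stands among these three with nothing to separate it: the value of compound 3 is nearest to it and that of compound 2 furthest, and both gaps lie within the usual scatter of repeated measurements. Going by the values given here, the only single-point step among the measured compounds is a 1.5-fold lower number from compound 2 to compound 3 (0.17 log units; within the scatter), and it too remains within the scatter.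

Compound 4 `COc1ccc(-c2cn(-c3cccc(C(=O)/C=C/c4cc(OC)c(OC)c(OC)c4)c3)c(=O)[nH]2)cc1` is reached from compound 1 by one change: methoxy in place of chloro on an aromatic carbon. Among the compounds with values here, no measured pair shows methoxy against chloro at this position, so the step from compound 2 to compound 3, which swaps a different pair of groups on the same ring, is the only guide, and it was small. On that basis the expectation for compound 4 is a step of no change at the digits printed from compound 1 to compound 4 (within the scatter), which is to say no change beyond the scatter. Compound 4 is therefore estimated at 1750 nM in this assay, with a range from 700 nM to 4500 nM.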

Compound 4, concentration for 50% growth inhibition: 450 nM
Estimate against measurement, compound 4: 3.9-fold (0.59 log units) above; measured number below the stated range.
By their numbers in this assay, from the lowest: compound 4; then compounds 3, 1 and 2 (each within the scatter of the next).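

In this assay, going by these compounds alone, the change from 4-chlorophenyl to 4-methoxyphenyl produces a 3.9-fold lower number from compound 1 to compound 4 (0.59 log units; beyond the scatter), a step beyond the scatter, whereas the only earlier step at this position, a 1.5-fold lower number from compound 2 to compound 3 (0.17 log units; within the scatter), stayed within it. The position on the aromatic carbon para to a large group is therefore not indifferent to the group it carries, something compounds 1, 2 and 3 could not show, since their values gave no step beyond the scatter. No measurement shown here accounts for the step, so the difference between methoxy and chloro at this position remains an observation without an explanation.

The compounds shown leave open whether the step reflects something gained with methoxy or something lost with chloro, since no pair here sets methoxy against hydrogen on the same background, and whether it would carry over to the background of compound 3. They also leave open how an amine, a carboxylic acid or a longer chain such as ethoxy would behave at this position.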